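Halophenyl ketone series: from compound 2 to compound 4

The source may hold more compounds than are shown below. What is called first, only, known or untested is meant among the compounds shown, and "the series" means these compounds.

Three compounds carry a number in a functional assay on THP-1 cells (Homo sapiens) for inhibition, read by ELISA, with stated times of 30 min and 24 h, tested at 10 uM (on this read-out lower numbers stand for a weaker effect and higher numbers for a stronger effect at the one concentration tested), so far. Compound 1 `COc1cc(OC)c(C(=O)c2cccc(Cl)c2)c(O)c1CN1CCCC1` gives 81% in this assay. Compound 2 `COc1cc(OC)c(C(=O)c2cccc(Cl)c2)c(O)c1CN1CCCCC1` gives 83% in this assay, and compound 3 `COc1cc(O)c(C(=O)c2cccc(F)c2)c(OC)c1`, which lacks the aminomethyl arm and carries a fluorine on the ketone aryl, gives 81% in this assay. Among the compounds with values here, the only single-place step measured is a number 2 percentage points higher from compound 1 to compound 2 (within the scatter). Compound 2 thus holds the highest of the three numbers, but its gaps to compound 1 and to compound 3 are both within the scatter, so no ordering is claimed.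

Compound 4 `COc1cc(OC)c(C(=O)c2ccccc2F)c(O)c1CN1CCCCC1` is the next target. Against compound 2 the change is 2-fluorophenyl in place of 3-chlorophenyl on a carbonyl carbon. Within the data shown here, no measured step touches the ketone aryl while the rest is held fixed; compound 3 differs from compound 2 in more than one place, so its value only shows that a fluorinated ketone aryl can sit at a comparable level. Among the measured compounds shown here, the one measured step, the amine ring swap, was within the scatter. On that basis a step of a number 4 percentage points lower from compound 2 to compound 4 (within the scatter) in this assay is expected, that is, nothing beyond the scatter. Compound 4 is therefore estimated at 79% in this assay, with a range from 64% to 92%.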

Compound 4, a percentage reported as activity, at one concentration (the size of the read-out at that concentration, not a potency): 84%
Estimate against measurement, compound 4: 5 percentage points below; the range from low to high includes it.
By their numbers in this assay, from the lowest: compounds 1, 3, 2 and 4 (each within the scatter of the next).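

In this assay, within the data shown here, a number 1 percentage points higher from compound 2 to compound 4 (within the scatter) is the first measured change at the ketone aryl with the rest of the structure held fixed, replacing 3-chlorophenyl with 2-fluorophenyl on a carbonyl carbon. This position therefore accepts this exchange of one halogenated phenyl for another without a read-out change beyond the scatter, which compound 3 could not show as it differs from compound 2 in more than one place. The kind of halogen and its place on the ring change together in this single step, so their separate contributions cannot be read, and nothing shown bears on why the number holds.

Still open, as far as these compounds go, is whether the ketone aryl stays at this level with no halogen at all, as a plain phenyl, or with a carboxylic acid or an amine on the ring. Also open, from the compounds shown here alone, is whether compounds that read alike at the one concentration tested also match in potency, which would take a full concentration series in this assay.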